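The source may report more compounds than this note shows. Statements on the series, on what has been measured and on what is new or still open speak of the compounds shown alone.

Values in a functional assay on HCT-116 cells (Homo sapiens) for cytotoxicity, read by MTT assay, with a stated time of 3 days; on this read-out higher numbers stand for weaker inhibition and lower numbers for stronger inhibition:
- compound 1 `CC(C)(C)c1cc2c(N/N=C/c3ccc(C(=O)O)cc3)ncnc2s1`: 9.99 ug/mL
- compound 2 `CC(C)(C)c1cc2c(N/N=C/c3ccc(CN)cc3)ncnc2s1`: 0.334 ug/mL
- compound 3 `CC(C)(C)c1cc2c(N/N=C/c3ccccc3)ncnc2s1`: "not determined" (no result reported)

Compound 3 has no number in this assay, so it gives no fixed point from which to step. Compound 4 `CN(C)S(=O)(=O)c1ccc(/C=N/Nc2ncnc3sc(C(C)(C)C)cc23)cc1` differs from compound 3 by dimethylsulfamoyl in place of hydrogen on an aromatic carbon, para to a large group.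

Among the compounds with values here, the only measured step is a 30-fold lower number from compound 1 to compound 2 (1.48 log units; beyond the scatter). It is large, lies beyond the scatter, and comes with aminomethyl in place of carboxy on an aromatic carbon. Neither of those groups is the one entering here, so this step gives no direction for compound 4. Within the data shown here, it shows only that one exchange on an aromatic carbon moved the number a long way in this pair.

Among the measured compounds shown here, with no starting value and no matching step, no step size or direction can be stated from compound 3. The estimate therefore rests on the span from compound 1 at 9.99 ug/mL to compound 2 at 0.334 ug/mL, and the range is kept wide. For compound 4 the expected value is 3 ug/mL, with an estimated range of 0.6 ug/mL to 15 ug/mL.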

Compound 4, half-maximal inhibitory concentration: 1.42 ug/mL
Compound 4: middle estimate off by 2.1-fold (0.32 log units), on the high side, and the stated range covers the measured number.
By their numbers in this assay, from the lowest: compound 2; then compound 4; then compound 1.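

In this assay, the aromatic carbon para to a large group now has three measured groups, and the exchange of aminomethyl for dimethylsulfamoyl gives a 4.3-fold higher number from compound 2 to compound 4 (0.63 log units; beyond the scatter), while the exchange of carboxy for dimethylsulfamoyl gives a 7.0-fold lower number from compound 1 to compound 4 (0.85 log units; beyond the scatter). Both steps lie beyond the scatter and point in opposite directions, so dimethylsulfamoyl sits inside the span set by the two earlier groups, and the position gives an intermediate value as well as the two ends seen before. Nothing measured here accounts for this order of the three groups.

With no number for compound 3 in this assay, the effect of any of these three groups relative to hydrogen at this position cannot be read, and the series has no unsubstituted reference point. As far as these compounds go, it also remains open where an unsubstituted sulfonamide, a dimethylamine, an amide or a longer aminoalkyl chain on the same carbon would fall relative to the aminomethyl and dimethylsulfamoyl groups, and whether the order of the three groups holds in other cell lines.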